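The source may hold more compounds than are shown below. What is called first, only, known or untested is meant among the compounds shown, and "the series" means these compounds.

Of the compounds shown here, two have been tested so far in a functional assay on MDA-MB-231 cells (Homo sapiens) for inhibition, read by sulforhodamine B assay, with a stated time of 72 h; a lower number here means a stronger inhibitor of growth, a higher number a weaker inhibitor of growth. Compound 1 `CN1CCN(C(=O)/C=C/c2ccncc2-c2ccc3ccccc3c2)CC1` gives > 10000 nM, which is a limit of the assay and not a number. Compound 2 `CCOC(=O)/C=C/c1ccncc1-c1ccc2[nH]ccc2c1` gives > 10000 nM, which is also a limit. Compound 2 therefore stands at the limit of > 10000 nM in this assay, at which 2 of the 2 values shown sit, and no exact value is known for it. Compound 3 `CCOC(=O)/C=C/c1ccncc1-c1ccc2c(ccn2C)c1` differs from compound 2 in one place: methyl in place of hydrogen on an aromatic nitrogen. Going by the values given here, no measured step is available to size this change, so the expectation rests on compound 2, whose > 10000 nM is a limit. The estimated step of an at least 1.2-fold lower number from compound 2 to compound 3 (0.09 log units; that floor lies within the scatter) is expected to be small, towards a stronger inhibitor of growth if it appears at all, and another limit is quite possible. The expected value for compound 3 is 8000 nM, within an estimated range of 1500 nM to 20000 nM.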

Compound 3, concentration for 50% growth inhibition: 10200 nM
Estimate against measurement, compound 3: 1.3-fold (0.11 log units) below; the range from low to high includes it.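

Compound 2 gives > 10000 nM, which is a limit and not a number, so the step from compound 2 to compound 3 cannot be read. These compounds leave open whether methyl in place of hydrogen on the aromatic nitrogen changes growth inhibition at all, and by how much.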